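Swapping a benzoyl amide for an amine

The source may hold more compounds than are shown below. What is called first, only, known or untested is meant among the compounds shown, and "the series" means these compounds.

Compound 1 `COc1cc2c(cc1C(C)NC(=O)c1ccccc1)C=CC(C)(C)O2` gives 34800 nM
Compound 2 `COc1cc2c(cc1C(C)NC(=O)/C=C/c1ccccc1)C=CC(C)(C)O2` gives 107000 nM
Compound 3 `COc1ccc(CNC(C)c2cc3c(cc2OC)OC(C)(C)C=C3)cc1` gives 14900 nM

In an ADME assay on L6 cells (Rattus norvegicus) for cytotoxicity (on this read-out higher numbers stand for weaker inhibition and lower numbers for stronger inhibition), compound 1 gives 34800 nM and sits in the middle of the three numbers, with compound 2 higher and compound 3 lower. Compound 4 `COc1cc2c(cc1C(C)N[C@H](C)c1ccccc1)C=CC(C)(C)O2` has 1-phenylethyl in place of benzoyl on an amine nitrogen and has not yet been measured.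

Among the measured compounds shown here, the only measured step between closely matched compounds is a 3.1-fold higher number from compound 1 to compound 2 (0.49 log units; beyond the scatter) when 2-phenylethenyl takes the place of phenyl on a carbonyl carbon. For the measured compounds named here, that step keeps the carbonyl, so it shows only that a change in this part of the molecule moved the number modestly. Compound 3 is the nearest guide, as it too has no carbonyl on that nitrogen, and compound 3 gives 14900 nM on this read-out, a lower number than compound 1 gives. One compound is thin evidence, so the expectation stays loose.

The expected change is a modest step of a 2.3-fold lower number from compound 1 to compound 4 (0.37 log units; beyond the scatter) towards stronger inhibition. The estimated value for compound 4 is 15000 nM with an expected range of 6000 nM to 40000 nM in this assay as measured here.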

Compound 4, half-maximal inhibitory concentration: 15900 nM
Beside the measured number, compound 4's estimate is 1.1-fold (0.03 log units) below it, within the range that was stated.
By their numbers in this assay, from the lowest: compounds 3 and 4 (each within the scatter of the next); then compound 1; then compound 2.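

In this assay, among the compounds shown here, 1-phenylethyl in place of benzoyl gives a 2.2-fold lower number from compound 1 to compound 4 (0.34 log units; beyond the scatter), the first closely matched step in which the carbonyl itself leaves this nitrogen rather than staying while the group behind it changes. The direction of the step is towards stronger inhibition, and it is opposite to that of a 3.1-fold higher number from compound 1 to compound 2 (0.49 log units; beyond the scatter), which keeps the carbonyl and moves towards weaker inhibition. The earlier hint from a single compound now has support, since compound 3 gives 14900 nM and compound 4 gives 15900 nM, two values within the scatter of each other from two different groups that both lack a carbonyl on that nitrogen.

No measurement shown here accounts for the step, so the reason for it stays unknown. Also open, on these data alone, is how much of the step belongs to the aromatic ring and how much to the defined stereocentre that 1-phenylethyl brings, which a cyclohexylmethyl group on the same nitrogen, or the mirror-image form of 1-phenylethyl, could help to separate.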